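Chloro for Fluoro on the Benzoyl Ring, Meta This Time

This account rests on a few compounds, and the source may have more. Where it says the series, first, only, none or still open, it means among the compounds named here.

Compound 1 `O=C(O)COC1CCN(CCN(C(=O)c2ccc(F)cc2)c2ccc(Cl)cc2)CC1` gives 2000 nM in a functional assay on a cell-free system (Platelet, plasma, Homo sapiens) for inhibition; a higher number here means a weaker inhibitor, a lower number a stronger inhibitor. Compound 2 `O=C(O)COC1CCN(CCN(C(=O)c2ccc(Cl)cc2)c2ccc(Cl)cc2)CC1` gives 1500 nM in this assay. Compound 3 `O=C(O)COC1CCN(CCN(C(=O)c2cccc(F)c2)c2ccc(Cl)cc2)CC1` gives 340 nM in this assay.

The unmeasured compound 4 `O=C(O)COC1CCN(CCN(C(=O)c2cccc(Cl)c2)c2ccc(Cl)cc2)CC1` arises from compound 3 by chloro in place of fluoro on an aromatic carbon. The same kind of change, (chloro in place of fluoro on an aromatic carbon), links compound 1 and compound 2, where it gave a 1.3-fold lower number from compound 1 to compound 2 (0.12 log units; within the scatter). The two cores differ by 3-fluorophenyl in place of 4-fluorophenyl on a carbonyl carbon, a rearrangement that gave a 5.9-fold lower number from compound 1 to compound 3 (0.77 log units; beyond the scatter). The places are not identical: in compound 1 the swapped atom sits para to a large group, in compound 3 meta to a large group, so this is the same kind of change, not the same. Because the earlier swap gave a 1.3-fold lower number from compound 1 to compound 2 (0.12 log units; within the scatter), the expected step for compound 4 is a 1.2-fold lower number from compound 3 to compound 4 (0.08 log units; within the scatter). Compound 4 is estimated at 280 nM, between 120 nM and 700 nM.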

Compound 4, half-maximal inhibitory concentration: 350 nM
Compound 4: the middle estimate sits 1.3-fold (0.10 log units) below what was measured; the range from low to high includes it.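

In this assay, chloro in place of fluoro on an aromatic carbon gave no step beyond the scatter on either core, and the two steps agree: the same change on two cores in this assay, a 1.3-fold lower number (0.12 log units; within the scatter) from compound 1 to compound 2 and a 1.0-fold higher number (0.01 log units; within the scatter) from compound 3 to compound 4, 1.4-fold (0.14 log units) apart, within the scatter of two such steps

The new step reads a 1.0-fold higher number from compound 3 to compound 4 (0.01 log units; within the scatter), while moving the halogen gave larger changes, with a 4.3-fold lower number from compound 2 to compound 4 (0.63 log units; beyond the scatter) and a 5.7-fold lower number from compound 1 to compound 4 (0.76 log units; beyond the scatter). So the swap carried over between these two closely related cores, but two pairs do not show that it would stay this small on a different core.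

From the compounds shown here alone, it remains open whether a methoxy or a nitrile in place of the chloro of the 3-chlorophenyl would also leave the number unchanged. Going by these compounds, whether the same swap matters on the other chlorinated aromatic ring also remains open.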